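Replacing 4-hydroxyphenyl with 3,5-dichlorophenyl

A few compounds are considered here, and "the series" means these few. Any claim that something is new, unique, unknown or untested is made for them only; others in the source may bear on it.

Of the compounds shown here, two on one shared core have numbers so far in a functional assay on HT-1080 cells (Homo sapiens) for cytotoxicity, read by MTT assay, with a stated time of 72 h (a lower number here means a stronger inhibitor, a higher number a weaker inhibitor), of this series. Compound 1 (`COc1ccc(/C=C2\CCC/C(=C\c3cccc(O)c3)C2=O)cc1OC`) gives 1700 nM with its 3-hydroxyphenyl group. Compound 2 (`COc1ccc(/C=C2\CCC/C(=C\c3ccc(O)cc3)C2=O)cc1OC`) gives 16800 nM with a 4-hydroxyphenyl group instead, and this is the highest of the two numbers. Compound 3 (`COc1ccc(/C=C2\CCC/C(=C\c3cc(Cl)cc(Cl)c3)C2=O)cc1OC`) keeps the core but exchanges that group for 3,5-dichlorophenyl on a double-bonded chain carbon bound to a double-bonded ring carbon (3,5-dichlorophenyl in place of 4-hydroxyphenyl on a double-bonded chain carbon bound to a double-bonded ring carbon). Among the compounds with values here, the one measured step at this place is modest but beyond the scatter (a 9.9-fold higher number from compound 1 to compound 2 (0.99 log units; beyond the scatter)) and leaves compound 2 at the higher end. Within the data shown here, no measured compound carries chlorine, so that step is only a rough guide. With the 4-hydroxyphenyl group of compound 2 gone, a lower number is expected in this assay of somewhat smaller size than the measured step (a 9.9-fold higher number from compound 1 to compound 2 (0.99 log units; beyond the scatter)). The expected change is a drop (a 5.6-fold lower number from compound 2 to compound 3 (0.75 log units; beyond the scatter)) and remains uncertain. Compound 3 is estimated at 3000 nM (expected range 800 nM to 12000 nM).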

Compound 3, half-maximal inhibitory concentration: 3000 nM
Beside the measured number, compound 3's estimate shows no gap at the digits printed; low and high end bracket the measured number.
By their numbers in this assay, from the lowest: compounds 1 and 3 (each within the scatter of the next); then compound 2.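

In this assay, the step of a 5.6-fold lower number from compound 2 to compound 3 (0.75 log units; beyond the scatter) shows that a hydroxyl is not needed on the group at this position for a number well below that of compound 2: 3,5-dichlorophenyl, with 0 hydrogen-bond donors and 0 hydrogen-bond acceptors, serves there. The step of a 1.8-fold higher number from compound 1 to compound 3 (0.25 log units; within the scatter) places the new group level with 3-hydroxyphenyl, so the two groups, which share no substituent, cannot be told apart in this assay, and among the three compounds only the 4-hydroxyphenyl group of compound 2 stands apart. The compounds shown offer no independent measurement that would explain either step.

From the compounds shown here alone, what remains open is whether the high number of compound 2 belongs to the 4-hydroxyphenyl group specifically, or whether other groups on the same carbon would follow it or follow compounds 1 and 3. A phenyl group carrying a single chlorine, an amine or a carboxylic acid would test this, and would also show whether both chlorines of compound 3 are needed to reach its number.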